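This account rests on a few compounds, and the source may have more. Where it says the series, first, only, none or still open, it means among the compounds named here.

In a functional assay on CNE-2 cells (Homo sapiens) for inhibition, read by MTT assay, with a stated time of 72 h (a higher number here means a weaker inhibitor, a lower number a stronger inhibitor), compound 1 `Nc1nc2cc(-c3nn(CCCCC(=O)NO)c4ncnc(N)c34)ccc2o1` and compound 2 `Nc1nc2cc(-c3nn(CCCCCCCCC(=O)NO)c4ncnc(N)c34)ccc2o1` share one core and differ only in the chain that ends in hydroxycarbamoyl. Compound 1 reads > 50000 nM, which is a limit of the assay and not a number. Going by the values given here, compound 2 gives 3240 nM, the only true number so far in this assay. Among the compounds with values here, the one measured step is an at least 15-fold lower number from compound 1 to compound 2 (1.18 log units; beyond the scatter), and its size rests on (the limit of > 50000 nM in this assay, at which 1 of the 2 values shown sits). Compound 3 `Nc1nc2cc(-c3nn(CCCCCCC(=O)NO)c4ncnc(N)c34)ccc2o1` comes next: hydroxycarbamoyl in place of 2-(hydroxycarbamoyl)ethyl on a saturated chain carbon, six bonds along the chain from an aromatic nitrogen. In words, hydroxycarbamoyl stands in place of 2-(hydroxycarbamoyl)ethyl on a saturated chain carbon, six bonds along the chain from an aromatic nitrogen. The chain of compound 3 is therefore shorter than that of compound 2 and longer than that of compound 1. The large step just described is the only one that bears on this change, and it suggests that part of that gain is lost on shortening. Two chain lengths cannot show where the loss sets in, so the expectation is loose. The expected change is moderate and upward, as a 2.5-fold higher number from compound 2 to compound 3 (0.39 log units; beyond the scatter). For compound 3 the estimate is 8000 nM, with an expected range of 1800 nM to 35000 nM.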

Compound 3, half-maximal inhibitory concentration: 4360 nM
Beside the measured number, compound 3's estimate is 1.8-fold (0.26 log units) above it; low and high end bracket the measured number.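

In this assay, putting hydroxycarbamoyl in place of 2-(hydroxycarbamoyl)ethyl on a saturated chain carbon, six bonds along the chain from an aromatic nitrogen, gives a 1.3-fold higher number from compound 2 to compound 3 (0.13 log units; within the scatter), so these two chain lengths read alike. With 2-(hydroxycarbamoyl)ethyl in place of hydroxycarbamoyl on a saturated chain carbon, four bonds along the chain from an aromatic nitrogen, the result is an at least 11-fold lower number from compound 1 to compound 3 (1.05 log units; beyond the scatter), so the large gain first seen with 4-(hydroxycarbamoyl)butyl at that place does not need the whole of that extension. The reading of compound 1 is a limit of the assay and not a number, and the size of this step rests on it: the limit of > 50000 nM in this assay, at which 1 of the 3 values shown sits.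

The compounds shown leave open at which chain length short of that of compound 3 the gain sets in, and whether a longer chain than that of compound 2 would lower the number further. They also leave open whether a carboxylic acid or an amine at the chain end, in place of hydroxycarbamoyl, would keep the numbers of compound 2 and compound 3.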